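Swapping fluoro for chloro on the benzyl ring

The compounds below may be only part of what the source reports. "The series", "measured", "known", "first", "only" and "open" are said of these compounds alone.

Measured compounds:
compound 1 `O=C(NOCc1ccccc1Cl)c1cn(-c2ccccc2)nc1-c1ccccc1`: 10300 nM
compound 2 `Cc1ccc(-c2nn(-c3ccccc3)cc2C(=O)NOCc2ccccc2Cl)cc1`: 380 nM
compound 3 `COc1ccc(-c2nn(-c3ccccc3)cc2C(=O)NOCc2ccccc2F)cc1`: 2160 nM

In a functional assay on A549 cells (Homo sapiens) for antiproliferative activity, read by MTT assay, with a stated time of 48 h, in the presence of a further agent that is not named here (a lower number here means a stronger inhibitor of growth, a higher number a weaker inhibitor of growth), compound 3 gives the second highest of the three numbers, between compound 1 and compound 2. Compound 4 `COc1ccc(-c2nn(-c3ccccc3)cc2C(=O)NOCc2ccccc2Cl)cc1` differs from compound 3 by chloro in place of fluoro on an aromatic carbon. Within the data shown here, the only measured step, a 27-fold lower number from compound 1 to compound 2 (1.43 log units; beyond the scatter), concerns a different place and a different group, so no measured step bears directly on this change. With nothing to show that chloro and fluoro here differ, the step of a 1.4-fold lower number from compound 3 to compound 4 (0.13 log units; within the scatter) is expected to stay within the scatter. Compound 4 is therefore estimated at 1600 nM, with a range from 500 nM to 5000 nM.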

Compound 4, concentration for 50% growth inhibition: 2450 nM
Estimate against measurement, compound 4: 1.5-fold (0.19 log units) below, within the range that was stated.
By their numbers in this assay, from the lowest: compound 2; then compounds 3 and 4 (each within the scatter of the next); then compound 1.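

In this assay, the step of a 1.1-fold higher number from compound 3 to compound 4 (0.05 log units; within the scatter) shows that chloro and fluoro on this benzyl ring cannot be told apart when methoxy is present. With chloro held fixed, methoxy in place of hydrogen gives a 4.2-fold lower number from compound 1 to compound 4 (0.62 log units; beyond the scatter), but methoxy in place of methyl gives a 6.4-fold higher number from compound 2 to compound 4 (0.81 log units; beyond the scatter), so methoxy keeps only part of the gain seen with methyl. No supporting data explain these differences.

Going by these compounds, whether chloro and fluoro also match when methyl or hydrogen replaces methoxy remains open. So does the effect of bromo on the benzyl ring, or of an amine or a carboxylic acid in place of methoxy.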